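The source may hold more compounds than are shown below. What is called first, only, known or untested is meant among the compounds shown, and "the series" means these compounds.

Measured in a functional assay on SMMC-7721 cells (Homo sapiens) for antiproliferative activity, read by MTT assay, with a stated time of 72 h; on this read-out higher numbers stand for weaker inhibition and lower numbers for stronger inhibition:
- compound 1 `C#CCSc1nc(Sc2nnnn2CCN(C)C)c(C#N)c(-c2ccc(Cl)cc2)n1`: 7340 nM
- compound 2 `C#CCSc1nc(Sc2nc[nH]n2)c(C#N)c(-c2cc(OC)c(OC)c(OC)c2)n1`: > 20000 nM, a limit
- compound 3 `C#CCSc1nc(Sc2nc3ccccc3s2)c(C#N)c(-c2cc(OC)c(OC)c(OC)c2)n1`: > 20000 nM, a limit

Among the measured compounds shown here, compound 1 is the only compound here with a real number, 7340 nM. The other two entries are limits and cannot be ranked against it in size.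

The next compound is compound 4 `C#CCSc1nc(Sc2nccs2)c(C#N)c(-c2ccc(Cl)cc2)n1`, which has 1,3-thiazol-2-yl in place of 1-(2-(dimethylamino)ethyl)-1H-tetrazol-5-yl on a sulfur.

For the measured compounds named here, the one measured change of group on such a sulfur is a step that the two limits leave unreadable from compound 2 to compound 3, so it gives no size to carry over. A further caution is the limit of > 20000 nM in this assay, at which 2 of the 3 values shown sit, so compound 4 may also return only a limit.

With no readable step, the expectation stays anchored on compound 1 at 7340 nM, with no direction favoured and no shift expected beyond the scatter. The estimated change is a 1.1-fold higher number from compound 1 to compound 4 (0.04 log units; within the scatter), though with wide uncertainty.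

For compound 4 the estimate is 8000 nM, with an expected range from 2500 nM to 20000 nM.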

Compound 4, half-maximal inhibitory concentration: 6040 nM
Compound 4: middle estimate off by 1.3-fold (0.12 log units), on the high side; low and high end bracket the measured number.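

In this assay, the group on the sulfur now has a readable step: a 1.2-fold lower number from compound 1 to compound 4 (0.08 log units; within the scatter). In this pair, 1,3-thiazol-2-yl with 5 heavy atoms takes the place of a group with 10 heavy atoms, and the values stay within the scatter of each other. The dimethylamino chain and the tetrazole ring are therefore not needed to keep a numerical value on the core shared by compound 1 and compound 4.

From the compounds shown here alone, compound 2 and compound 3 each give only a limit, and the step between them cannot be read: the limit of > 20000 nM in this assay, at which 2 of the 4 values shown sit. Whether a morpholine ring or a carboxylic acid on a chain at this sulfur would move the number beyond the scatter remains open.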